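This account rests on a few compounds, and the source may have more. Where it says the series, first, only, none or still open, it means among the compounds named here.

Of the compounds shown here, two with a shared core have been tested so far in a functional assay on MIA PaCa-2 cells (Homo sapiens) for inhibition, read by MTT assay, with a stated time of 48 h, tested at 10 uM; a higher number here means more inhibition of growth at the concentration tested, a lower number less inhibition of growth. Compound 1 (`Cc1cc(=O)c2c(O)c(CN3CCN(C(=O)OC(C)(C)C)CC3)c(O)c([C@H]3CCN(C)C[C@H]3O)c2o1`) gives 6%, and compound 2 (`Cc1cc(=O)c2c(O)c(CN3CCCC3CO)c(O)c([C@H]3CCN(C)C[C@H]3O)c2o1`) gives 13%. These two numbers lie within the scatter of each other, so compound 2 stands level with compound 1, and neither number is large on this scale.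

Compound 3 (`Cc1cc(=O)c2c(O)c(CN3CCCCC3)c(O)c([C@H]3CCN(C)C[C@H]3O)c2o1`) has yet to be measured in this assay. It differs from compound 2 on a saturated chain carbon bound to an aromatic carbon, where piperidin-1-yl takes the place of 2-(hydroxymethyl)pyrrolidin-1-yl: piperidin-1-yl in place of 2-(hydroxymethyl)pyrrolidin-1-yl on a saturated chain carbon bound to an aromatic carbon. Within the data shown here, no measured pair differs in one place only, so the data hold no direct precedent for this change. Among the measured compounds shown here, the only guide is the pair of values themselves, compound 1 at 6% and compound 2 at 13%. On that basis, no step beyond the scatter is expected, in either direction. The expected step of a number 1 percentage points higher from compound 2 to compound 3 (within the scatter) is therefore small. For compound 3 the estimated value is 14%, with an expected range from 2% to 30%.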

Compound 3, percent growth inhibition at one concentration: 14%
Estimate against measurement, compound 3: no gap at the digits printed; measured number inside the range.
By their numbers in this assay, from the lowest: compounds 1, 2 and 3 (each within the scatter of the next).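

Among these compounds, the step of a number 1 percentage points higher from compound 2 to compound 3 (within the scatter) in this assay is the first comparison that differs in one place only, so it gives this position its first direct reading. On the saturated chain carbon bound to an aromatic carbon, the five-membered non-aromatic ring of 2-(hydroxymethyl)pyrrolidin-1-yl, with 1 hydrogen-bond donor and 2 hydrogen-bond acceptors, can give way to the six-membered non-aromatic ring of piperidin-1-yl, with 0 hydrogen-bond donors and 1 hydrogen-bond acceptor, with no step beyond the scatter. Nothing available here bears on the reason for this result.

A single step cannot separate the ring size from the loss of the hydroxymethyl group, so the compounds shown do not tell whether either change alone would read the same way. Also open, on these data alone, is whether any group at this place can lift the number clearly above the scatter, for instance a morpholin-4-yl ring, a piperidin-1-yl ring carrying a carboxylic acid, or an open dialkylamine with a longer chain.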